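The source may report more compounds than this note shows. Statements on the series, on what has been measured and on what is new or still open speak of the compounds shown alone.

Measured compounds:
compound 1, `COc1cc(Cl)cc(-c2nn(-c3cccc(NC(=O)c4ccc(Cl)c(Cl)c4)c3)cc2-c2ccncc2)c1`, 43.6%
compound 2, `COc1cc(Cl)cc(-c2nn(-c3cccc(NC(=O)Nc4cc(C(F)(F)F)cc(C(F)(F)F)c4)c3)cc2-c2ccncc2)c1`, -37.9%

In a functional assay on SR cells (Homo sapiens) for inhibition, read by sulforhodamine B assay, with a stated time of 48 h, tested at 10 uM (on this read-out higher numbers stand for a weaker effect at the one concentration tested and lower numbers for a stronger effect), compound 1 gives the higher of the two numbers, so the weaker effect; compound 2 gives a number far lower, beyond the scatter. No single-point step between the two is shown, as they differ in more than one place.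

Compound 3, `COc1cc(Cl)cc(-c2nn(-c3cccc(NC(=O)Nc4ccc(Cl)c(Cl)c4)c3)cc2-c2ccncc2)c1`, is not yet measured. It differs from compound 1 by (3,4-dichlorophenyl)amino in place of 3,4-dichlorophenyl on a carbonyl carbon. A step downward, beyond the scatter, is expected for a number 38.6 percentage points lower from compound 1 to compound 3 (beyond the scatter), because compound 2, also a urea, gives -37.9%. Compound 3 is estimated at 5%, within -35% to 40%.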

Compound 3, a percentage reported as activity, at one concentration (the size of the read-out at that concentration, not a potency): -18.5%
For compound 3 the middle estimate is 23.5 percentage points above the measured one; the measured number falls inside the stated range.
By their numbers in this assay, from the lowest: compound 2; then compound 3; then compound 1.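

Holding the 3,4-dichlorophenyl fixed, (3,4-dichlorophenyl)amino in place of 3,4-dichlorophenyl on a carbonyl carbon gives in this assay a step of a number 62.1 percentage points lower from compound 1 to compound 3 (beyond the scatter) and so moves the read-out towards the stronger effect. For the compounds shown here, this is the first single-place reading of the change from amide to urea, and it shows that this position responds strongly to the added amino link. No measured evidence bears on the origin of this step.

Still open, from the compounds shown here alone, is whether a thiourea or a methylene link at this carbonyl carbon would behave like the urea. A methyl group on the urea nitrogen is also untested among the compounds shown.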